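This account rests on a few compounds, and the source may have more. Where it says the series, first, only, none or still open, it means among the compounds named here.

Measured so far:
- compound 1 `Cc1cc(=O)n(-c2cccc(F)c2)nc1C(=O)Nc1ccc(Oc2ncnc3ccsc23)cc1`: 9540 nM
- compound 2 `Cc1ccc(-n2nc(C(=O)Nc3ccc(Oc4ncnc5ccsc45)cc3)c(C)cc2=O)cc1`: 11500 nM
- compound 3 `Cc1cc(=O)n(-c2cccc(F)c2)nc1C(=O)Nc1ccc(Oc2ncnc3sccc23)cc1`: 16400 nM

The three measured compounds share the amide-linked arrangement and differ at two places: the group on the aromatic nitrogen and the bicyclic group on the ether oxygen. In a functional assay on A549 cells (Homo sapiens) for cytotoxicity, read by MTT assay, with a stated time of 72 h (a higher number here means a weaker inhibitor, a lower number a stronger inhibitor), compound 1 gives 9540 nM. Compound 2 differs from compound 1 by 4-methylphenyl in place of 3-fluorophenyl on an aromatic nitrogen. In this assay compound 2 gives 11500 nM, a step of a 1.2-fold higher number from compound 1 to compound 2 (0.08 log units; within the scatter). Compound 3 differs from compound 1 by a group of 9 heavy atoms (6 carbon, 2 nitrogen, 1 sulfur; one five-membered aromatic ring with 1 hetero atom, one six-membered aromatic ring with 2 hetero atoms) in place of a group of 9 heavy atoms (6 carbon, 2 nitrogen, 1 sulfur; one five-membered aromatic ring with 1 hetero atom, one six-membered aromatic ring with 2 hetero atoms), on an oxygen on an aromatic ring; the two cores have the same atoms joined differently. In this assay compound 3 gives 16400 nM, a step of a 1.7-fold higher number from compound 1 to compound 3 (0.24 log units; within the scatter). All three values sit within the usual scatter of one another, so no order among them is claimed.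

Compound 4 `Cc1ccc(-n2nc(C(=O)Nc3ccc(Oc4ncnc5sccc45)cc3)c(C)cc2=O)cc1` has not yet been measured. It differs from compound 3 by 4-methylphenyl in place of 3-fluorophenyl on an aromatic nitrogen, the same change as from compound 1 to compound 2, at the same place. Since that change gave a 1.2-fold higher number from compound 1 to compound 2 (0.08 log units; within the scatter) on the core of compound 1, the expected step on the core of compound 3 is a 1.2-fold higher number from compound 3 to compound 4 (0.06 log units; within the scatter). Compound 4 is accordingly estimated at 19000 nM, with an expected range from 9000 nM to 40000 nM.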

Compound 4, half-maximal inhibitory concentration: > 40000 nM
Compound 4: only a limit was reported; the forecaster's own chance of this, stated with the estimate: 5%; middle value at least 2.1-fold (0.32 log units) from the limit.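

In this assay compound 4 gives > 40000 nM, which is a limit of the assay and not a number. Moving 4-methylphenyl in place of 3-fluorophenyl onto the other core gives an at least 2.4-fold higher number from compound 3 to compound 4 (0.38 log units; beyond the scatter), so the step on this core lies beyond the scatter, but a real difference from the step on the first core is suggested and not established: the same change on two cores in this assay, a 1.2-fold higher number (0.08 log units; within the scatter) from compound 1 to compound 2 and an at least 2.4-fold higher number (0.38 log units; beyond the scatter) from compound 3 to compound 4; the limit leaves it open whether they differ. The change of core with 4-methylphenyl in place gives an at least 3.4-fold higher number from compound 2 to compound 4 (0.54 log units; beyond the scatter), and this comparison likewise does not show whether the effect of either change depends on the other: the same change on two cores in this assay, a 1.7-fold higher number (0.24 log units; within the scatter) from compound 1 to compound 3 and an at least 3.4-fold higher number (0.54 log units; beyond the scatter) from compound 2 to compound 4; the limit leaves it open whether they differ.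

From the compounds shown here alone, the size of the step to compound 4 stays open, and with it whether the two changes add up or interact. The compounds shown also leave open how the two cores compare with a group other than these two substituted phenyl rings on the aromatic nitrogen, such as a pyridine ring, an amine or a carboxylic acid on the phenyl ring.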